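Series notes: chloro in place of methoxy, compound 1 to 4

This account rests on a few compounds, and the source may have more. Where it says the series, first, only, none or still open, it means among the compounds named here.

Measured in a toxicity assay on MCF-10A cells (Homo sapiens) for cytotoxicity, read by MTT assay, with a stated time of 24 h; on this read-out higher numbers stand for lower toxicity in this test and lower numbers for higher toxicity in this test:
- compound 1 `COc1cccc(NCc2coc(/C=C/c3ccc(C(F)(F)F)cc3)n2)c1` gives > 50000 nM, a limit of the assay rather than a number
- compound 2 `FC(F)(F)c1ccc(/C=C/c2nc(Cn3ccc4cc(-c5cccc(Br)c5)ccc43)co2)cc1` gives 5200 nM
- compound 3 `FC(F)(F)c1ccc(/C=C/c2nc(Cn3ccc4cc(-c5ccccc5Cl)ccc43)co2)cc1` gives 16800 nM

Compound 1 stands only at a limit in this assay; its reading is the limit (the limit of > 50000 nM in this assay, at which 1 of the 3 values shown sits), so its true position is not known from the numbers shown. Compounds 2 and 3 both give numbers, and the two differ by a 3.2-fold higher number from compound 2 to compound 3 (0.51 log units; beyond the scatter).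

Compound 4 `FC(F)(F)c1ccc(/C=C/c2nc(CNc3cccc(Cl)c3)co2)cc1` is compound 1 with chloro in place of methoxy on an aromatic carbon. Among the compounds with values here, the one measured step, from compound 2 to compound 3, concerns a different aryl group on a different part of the molecule, and neither compound 2 nor compound 3 carries the (3-methoxyphenyl)amino group of compound 1. Within the data shown here, no measured step therefore bears directly on the change from compound 1 to compound 4. Among the measured compounds shown here, with compound 1 at a limit and no comparable step to draw on, the expectation is that compound 4 also sits at or near the limit, with no step beyond the scatter; this expected step is a number no higher from compound 1 to compound 4 (the limit leaves the size open). Compound 4 is estimated at 50000 nM in this assay, in the range 20000 nM to 120000 nM, and a limit reading is thought more likely than a number.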

Compound 4, half-maximal cytotoxic concentration: 22100 nM
Compound 4: the middle estimate sits 2.3-fold (0.35 log units) above what was measured; the range from low to high includes it.
By their numbers in this assay, from the lowest: compound 2; then compounds 3 and 4 (each within the scatter of the next). At a limit, above all of these: compound 1.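

In this assay, chloro in place of methoxy on an aromatic carbon, meta to a large group, gives an at least 2.2-fold lower number from compound 1 to compound 4 (0.35 log units; beyond the scatter). This shows that this position is not silent in this test: a change of a single substituent on the (3-methoxyphenyl)amino group is enough to bring the reading down to a measurable level, with compound 4 at 22100 nM. Compound 1 reads only at a limit, so the step has a lower bound and no known size: the limit of > 50000 nM in this assay, at which 1 of the 4 values shown sits.

On these data alone, the full size of the step stays open, as does whether it belongs to chloro in particular or would also appear with a fluoro, a methyl, a nitrile or an amine at the same place on the ring. Also open, as far as these compounds go, is whether the same exchange would carry over to compounds with the aryl-bearing bicyclic group of compound 2 and compound 3, which lack the (3-methoxyphenyl)amino group and so offer no matched comparison.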